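This account rests on a few compounds, and the source may have more. Where it says the series, first, only, none or still open, it means among the compounds named here.

Compound 1 `CS(=O)(=O)c1ccccc1NCc1c[nH]cn1` was tested in a functional assay for activation of Alpha-1B adrenergic receptor (Homo sapiens); a higher number here means that more compound is needed for the effect, a lower number that less compound is needed. There compound 1 gives < 100000 nM, which is a limit of the assay rather than a number. Compound 2 `c1ccc(-c2ccccc2OCc2c[nH]cn2)cc1` was also tested, and in this assay compound 2 gives < 100000 nM, again only a limit. Within the data shown here, both values sit at the limit of < 100000 nM in this assay, at which 2 of the 2 values shown sit, so no measured step between the compounds exists. Compound 3 `c1ccc(-c2cnco2)c(NCc2c[nH]cn2)c1` differs from compound 1 by 1,3-oxazol-5-yl in place of methylsulfonyl on an aromatic carbon. With only limits in hand, the step from compound 1 to compound 3 is expected to be a step that the limit leaves unreadable from compound 1 to compound 3, with no firm direction. Compound 3 is estimated at 10000 nM, expected between 1000 nM and 100000 nM.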

Compound 3, half-maximal effective concentration: < 5020 nM
Compound 3 was reported as a limit (the forecaster's own chance of this, stated with the estimate: 50%); middle value at least 1.9-fold (0.29 log units) from the limit.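

Compound 1 and compound 3 are both reported in this assay only as limits, so the step between them cannot be read. The compounds shown leave open whether 1,3-oxazol-5-yl in place of methylsulfonyl changes the concentration needed at all.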